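Methoxy addition across two cores: cytotoxicity notes

The compounds below may be only part of what the source reports. "The series", "measured", "known", "first", "only" and "open" are said of these compounds alone.

Measured compounds:
compound 1, `COc1ccc(/C=C/C(=O)CC(C)=O)cc1OC`, in a functional assay on S1 cells (Homo sapiens) for cytotoxicity, read by MTT assay, with a stated time of 72 h (on this read-out lower numbers stand for stronger inhibition and higher numbers for weaker inhibition), gives 9300 nM.
compound 2, `COc1ccc(/C=C/C(=O)CC(C)=O)cc1`, in this assay gives 44600 nM.
compound 3, `Cc1cc(/C=C/c2ccc(O)cc2)on1`, in this assay gives 44200 nM.

For the measured compounds named here, the one counted step so far is methoxy in place of hydrogen on an aromatic carbon, which gives a 4.8-fold lower number from compound 2 to compound 1 (0.68 log units; beyond the scatter). Compound 3 carries a different core; how it differs from compound 2 is not broken down here, and the two values show compound 2 and compound 3 within the scatter of each other in this assay.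

Compound 4, `COc1cc(/C=C/c2cc(C)no2)ccc1O`, is not yet measured. It differs from compound 3 by methoxy in place of hydrogen on an aromatic carbon. Going by the values given here, this is the same kind of change as the one from compound 2 to compound 1, but not the same: in compound 1 the methoxy enters ortho to a methoxy group, whereas in compound 4 it enters ortho to a hydroxy group, on a different core, and no step on this core has been measured.

The expectation for compound 4 rests on the step from compound 2 to compound 1 in this assay, discounted for the change of core and of the neighbouring group; a smaller step is expected, a 2.8-fold lower number from compound 3 to compound 4 (0.44 log units; beyond the scatter). Compound 4 is estimated at 16000 nM in this assay, between 5000 nM and 45000 nM.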

Compound 4, half-maximal inhibitory concentration: 50500 nM
Compound 4: the middle estimate sits 3.2-fold (0.50 log units) below what was measured, and the stated range ends below it.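

In this assay, methoxy in place of hydrogen on an aromatic carbon, entering ortho to a hydroxy group on the core of compound 3, gives a 1.1-fold higher number from compound 3 to compound 4 (0.06 log units; within the scatter), so no readable shift appears on this core. Set beside the earlier step, the same change does not carry over in size from one core to the other: the same change on two cores in this assay, a 4.8-fold lower number (0.68 log units; beyond the scatter) from compound 2 to compound 1 and a 1.1-fold higher number (0.06 log units; within the scatter) from compound 3 to compound 4, 5.5-fold (0.74 log units) apart, beyond the scatter of two such steps. This shows that the step seen on the core of compound 1 cannot be treated as a fixed increment in this series, but it does not show whether the core or the neighbouring group accounts for the gap, as the two pairs differ in both at once (a methoxy group on the ring of compound 1, a hydroxy group on the ring of compound 4) and each step rests on a single pair.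

The compounds shown leave open how the same methoxy step would behave on the core of compound 3 with a methoxy group standing in place of the hydroxy group, a pair that would separate the core from the neighbouring group. Also open, as far as these compounds go, is whether other groups at this place, such as a fluorine atom or an amine, would move the value on either core.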